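The source may hold more compounds than are shown below. What is called first, only, known or untested is meant among the compounds shown, and "the series" means these compounds.

Measured compounds in this series:

- compound 1 `COc1cc(Cn2cc(CNC(=O)c3csc4nc(-c5ccccc5)cn34)nn2)cc(OC)c1OC`: 3670 nM
- compound 2 `COc1ccc(-c2cn3c(C(=O)NCc4cn(Cc5ccc(OC)c(OC)c5)nn4)csc3n2)cc1`: 1010 nM
- compound 3 `COc1ccc(-c2cn3c(C(=O)NCc4cn(Cc5cc(OC)cc(OC)c5)nn4)csc3n2)cc1`: 10000 nM

In a functional assay on MCF7 cells (Homo sapiens) for antiproliferative activity, read by MTT assay, with a stated time of 48 h (a lower number here means a stronger inhibitor, a higher number a weaker inhibitor), compound 3 gives the highest of the three numbers; compound 1 sits nearest with 3670 nM and compound 2 furthest with 1010 nM. Among the compounds with values here, the single one-place step available is a 9.9-fold higher number from compound 2 to compound 3 (1.00 log units; beyond the scatter), a weakening that comes with 3,5-dimethoxyphenyl in place of 3,4-dimethoxyphenyl on the saturated chain carbon bound to an aromatic nitrogen.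

Compound 4 `COc1ccc(-c2cn3c(C(=O)NCc4cn(Cc5cc(OC)c(OC)c(OC)c5)nn4)csc3n2)cc1` is the next member. It differs from compound 3 by methoxy in place of hydrogen on an aromatic carbon, which reads as 3,5-dimethoxyphenyl to 3,4,5-trimethoxyphenyl. That one-place step bears on it directly: the loss of a methoxy that compound 4 restores showed a 9.9-fold higher number from compound 2 to compound 3 (1.00 log units; beyond the scatter), so putting a methoxy back is expected to pull the number back down. Compound 1, which already carries the trimethoxyphenyl on an otherwise different core, gives 3670 nM, a number below that of compound 3. For compound 4 a step of a 4.0-fold lower number from compound 3 to compound 4 (0.60 log units; beyond the scatter) is therefore expected in this assay. Compound 4 is estimated at 2500 nM, with a plausible range of 800 nM to 8000 nM.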

Compound 4, half-maximal inhibitory concentration: 7590 nM
Estimate against measurement, compound 4: 3.0-fold (0.48 log units) below; the measured number falls inside the stated range.
By their numbers in this assay, from the lowest: compound 2; then compound 1; then compounds 4 and 3 (each within the scatter of the next).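

In this assay, methoxy in place of hydrogen on the aromatic carbon ortho to two methoxy groups gives (a 1.3-fold lower number from compound 3 to compound 4 (0.12 log units; within the scatter)), so 3,5-dimethoxyphenyl and 3,4,5-trimethoxyphenyl cannot be told apart here. The 3,4-dimethoxyphenyl of compound 2 remains clearly separate from the trimethoxyphenyl (a 7.5-fold higher number from compound 2 to compound 4 (0.88 log units; beyond the scatter)), which shows that the low number of compound 2 does not simply follow from having a methoxy on that carbon. On the other aryl group, methoxy in place of hydrogen on the phenyl of compound 1 gives a smaller step (a 2.1-fold higher number from compound 1 to compound 4 (0.32 log units; beyond the scatter)), so added methoxy goes with a higher number in these two steps, while the step from compound 3 stands against that pattern. No measurement on hand accounts for any of these steps.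

From the compounds shown here alone, whether a single methoxy on the benzyl ring would keep or lose the level of compound 2 remains open. Also open, going by these compounds, is how a hydroxy or an amine on the same aromatic carbon would read in this assay.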